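A Dimethoxyphenyl End Group Replaces the Chlorophenyl

A few compounds are considered here, and "the series" means these few. Any claim that something is new, unique, unknown or untested is made for them only; others in the source may bear on it.

Among the measured compounds shown here, in a functional assay on Gurav cells (Homo sapiens) for inhibition, read by sulforhodamine B assay (a higher number here means a weaker inhibitor of growth, a lower number a stronger inhibitor of growth), compound 1 `Oc1ccc(-c2ccc(-c3ccc(-c4nc5ccccc5[nH]4)cc3)cc2)cc1` gives 100000 nM and compound 2 `Clc1cccc(-c2ccc(-c3ccc(-c4nc5ccccc5[nH]4)cc3)cc2)c1` gives 2190 nM which makes compound 2 the lower of the only two numbers so far. Compound 3 `COc1ccc(-c2ccc(-c3ccc(-c4nc5ccccc5[nH]4)cc3)cc2)cc1OC` changes one end group, with 3,4-dimethoxyphenyl in place of 3-chlorophenyl on an aromatic carbon and the rest of the structure untouched. For the measured compounds named here, one measured step bears on this change: a 46-fold lower number from compound 1 to compound 2 (1.66 log units; beyond the scatter) when 3-chlorophenyl replaced 4-hydroxyphenyl. That step shows that this end group can shift the number strongly. Like compound 1 at 100000 nM compound 3 has oxygen on this ring and no chlorine, yet no methoxy compound has been measured. A partial move back is therefore expected. The estimated change is a 3.2-fold higher number from compound 2 to compound 3 (0.50 log units; beyond the scatter) toward weaker inhibition of growth. Compound 3 is expected at 7000 nM within an estimated range of 1500 nM to 35000 nM in this assay for now.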

Compound 3, concentration for 50% growth inhibition: 9230 nM
Compound 3: the middle estimate sits 1.3-fold (0.12 log units) below what was measured; low and high end bracket the measured number.
By their numbers in this assay, from the lowest: compound 2; then compound 3; then compound 1.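

In this assay, oxygen on the end ring does not by itself bring the number back up to that of compound 1: the comparison gives an 11-fold lower number from compound 1 to compound 3 (1.03 log units; beyond the scatter). The 3-chlorophenyl group still holds the lowest number of the three, with a 4.2-fold higher number from compound 2 to compound 3 (0.62 log units; beyond the scatter), so the two end groups without a hydroxyl lie well below compound 1 but remain distinct from each other. Nothing shown gives a reason for these differences.

Compound 3 differs from compound 2 in both the kind and the number of groups on the ring, so the compounds shown cannot tell whether a single methoxy group would behave like the pair. Going by these compounds, how an amine, a carboxylic acid or a longer ether chain on this ring would move the number also remains open.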